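Changing One Ring Substituent on the Way to Compound 3

The source may hold more compounds than are shown below. What is called first, only, known or untested is meant among the compounds shown, and "the series" means these compounds.

Measured so far:
compound 1, `O=C1C=COC(/C=C/c2ccccc2)C1`: 124 uM
compound 2, `O=C1C=CCC(/C=C/c2ccc(C(F)(F)F)cc2)O1`: 36.2 uM

In a functional assay on HT-29 cells (Homo sapiens) for inhibition, read by sulforhodamine B assay, with a stated time of 48 h (a higher number here means a weaker inhibitor of growth, a lower number a stronger inhibitor of growth), compound 2 stands at the lowest of the two numbers; compound 1 sits at a higher number, and the gap between the two lies beyond the usual scatter of repeated measurements. The two compounds differ in more than one place, so the data show no single step that explains the gap.

Compound 3, `COc1ccc(/C=C/C2CC=CC(=O)O2)cc1`, shares its core with compound 2 and differs from it in one place: methoxy in place of trifluoromethyl on an aromatic carbon. Within the data shown here, no measured pair shows what this change does, so the expectation rests on compound 2 alone. A modest shift is expected, most likely toward a higher number, that is a slightly weaker inhibitor of growth, with a fair chance of no change beyond the scatter. The estimate for compound 3 in this assay is 65 uM, with a range from 25 uM to 170 uM. The step this implies, a 1.8-fold higher number from compound 2 to compound 3 (0.25 log units; within the scatter), is an expectation, not a measurement.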

Compound 3, concentration for growth inhibition (reported as GI): 33.7 uM
Compound 3: middle estimate off by 1.9-fold (0.29 log units), on the high side; low and high end bracket the measured number.
By their numbers in this assay, from the lowest: compounds 3 and 2 (each within the scatter of the next); then compound 1.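

In this assay, among these compounds, putting methoxy in place of trifluoromethyl on the aromatic carbon gives a 1.1-fold lower number from compound 2 to compound 3 (0.03 log units; within the scatter), a step within the usual scatter and the first direct reading of this change. At this one position, then, two groups with different atoms and different hydrogen-bond acceptor counts give numbers that this assay cannot tell apart. No measured property of these compounds is available to explain this result.

Going by these compounds, it remains open whether an amine or a carboxylic acid on the same aromatic carbon would move the number beyond the scatter, and what a longer chain such as butoxy would do there. Also open, on these data alone, is whether the same exchange would give a similar result on the core of compound 1, which carries neither group.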